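Trading 4-fluorophenyl for 3-chlorophenyl on the shared core

A few compounds are considered here, and "the series" means these few. Any claim that something is new, unique, unknown or untested is made for them only; others in the source may bear on it.

In a functional assay on HL-60 cells (Homo sapiens) for inhibition, read by MTT assay, with a stated time of 72 h (a lower number here means a stronger inhibitor, a higher number a weaker inhibitor), compound 1 (`Cc1nc(-c2ccc(F)cc2)c(C(=O)N2CCN(c3cccc(Cl)c3)CC2)o1`) gives 40.1 nM and compound 3 (`CCc1nc(-c2ccc(F)cc2)c(C(=O)N2CCN(c3cccc(Cl)c3)CC2)o1`) gives 169 nM while compound 2 (`Cc1ccc(C)c(N2CCN(C(=O)c3oc(C)nc3-c3ccc(F)cc3)CC2)c1`) gives 358 nM as the highest number of the three. Compound 4 (`Cc1ccc(C)c(N2CCN(C(=O)c3oc(C)nc3-c3cccc(Cl)c3)CC2)c1`) has not been measured yet. It differs from compound 2 in one place, with 3-chlorophenyl in place of 4-fluorophenyl on an aromatic carbon. Neither measured step touches that place. Going by the values given here, a swap on an amine nitrogen in a ring gave an 8.9-fold higher number from compound 1 to compound 2 (0.95 log units; beyond the scatter) and a methyl added on a saturated chain carbon gave a 4.2-fold higher number from compound 1 to compound 3 (0.62 log units; beyond the scatter) so these steps show only that one change elsewhere can move the number beyond the scatter. They give no direction for this swap. The expected size is therefore a 1.1-fold higher number from compound 2 to compound 4 (0.03 log units; within the scatter) in this assay with no direction favoured and a wide margin either way. Compound 4 is expected near 380 nM with 120 nM to 1200 nM as the estimated range.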

Compound 4, half-maximal inhibitory concentration: 345 nM
Estimate against measurement, compound 4: 1.1-fold (0.04 log units) above; measured number inside the range.
By their numbers in this assay, from the lowest: compound 1; then compound 3; then compounds 4 and 2 (each within the scatter of the next).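

In this assay, 3-chlorophenyl in place of 4-fluorophenyl gives a 1.0-fold lower number from compound 2 to compound 4 (0.02 log units; within the scatter), so compound 2 and compound 4 cannot be told apart. Going by these compounds alone, this is the first reading at this position, and it shows that, with 2,5-dimethylphenyl on the ring amine nitrogen, the halogen and its place on the phenyl ring can both change without a shift beyond the scatter. No measurement here accounts for this outcome.

From the compounds shown here alone, because both features change in one step, the separate contribution of each stays open, and 3-fluorophenyl or 4-chlorophenyl would be needed to separate them. Also open, going by these compounds, are whether the swap behaves the same with the 3-chlorophenyl group of compound 1 on the ring amine nitrogen, and how an amine or a carboxylic acid on this phenyl ring would read.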